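This account rests on a few compounds, and the source may have more. Where it says the series, first, only, none or still open, it means among the compounds named here.

Measured in a functional assay on PC-9 cells (Homo sapiens) for inhibition, read by MTT assay, with a stated time of 72 h; on this read-out lower numbers stand for stronger inhibition and higher numbers for weaker inhibition:
- Compound 1 `Cc1cc(Nc2cc(-c3ccccc3)[nH]n2)n2nc(SCc3c(Cl)cccc3Cl)nc2n1`: 5180 nM
- Compound 2 `Cc1cc(Nc2cc(-c3ccccc3)[nH]n2)n2nc(SCc3ccc([N+](=O)[O-])cc3)nc2n1`: 7980 nM
- Compound 3 `CCCCCc1c(C)nc2nc(SCc3ccc(Cl)cc3)nn2c1Nc1cc(-c2ccccc2)[nH]n1`: > 50000 nM, a limit and not a number

Only compound 1 and compound 2 give numbers in this assay, and these two cannot be put in order, since the step between them is a 1.5-fold higher number from compound 1 to compound 2 (0.19 log units; within the scatter). For the measured compounds named here, compound 1 therefore stands level with its one numbered neighbour, at 5180 nM. Going by the values given here, compound 3 gives only a limit, and no step from it has been measured, so it offers no guidance here: the limit of > 50000 nM in this assay, at which 1 of the 3 values shown sits.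

Compound 4 `Cc1cc(Nc2cc(-c3ccccc3)[nH]n2)n2nc(SCc3cccc(Br)c3)nc2n1` has not yet been measured. Its difference from compound 1 is 3-bromophenyl in place of 2,6-dichlorophenyl on a saturated chain carbon bound to a sulfur. In words, it carries 3-bromophenyl in place of 2,6-dichlorophenyl on a saturated chain carbon bound to a sulfur.

Among the compounds with values here, one measured step bears on this change, as it replaces the same 2,6-dichlorophenyl at the same place, there with 4-nitrophenyl: a 1.5-fold higher number from compound 1 to compound 2 (0.19 log units; within the scatter). One step is thin support, but it gives no reason to expect a change beyond the scatter in either direction, so none is expected in this assay. The expected step reads a 1.2-fold higher number from compound 1 to compound 4 (0.06 log units; within the scatter). Compound 4 is expected at 6000 nM, with an estimated range of 2000 nM to 16000 nM.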

Compound 4, half-maximal inhibitory concentration: 8900 nM
Compound 4: the middle estimate sits 1.5-fold (0.17 log units) below what was measured, within the range that was stated.
By their numbers in this assay, from the lowest: compounds 1, 2 and 4 (each within the scatter of the next). At a limit, above all of these: compound 3.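

In this assay, a second replacement of the 2,6-dichlorophenyl on a saturated chain carbon bound to a sulfur gives a 1.7-fold higher number from compound 1 to compound 4 (0.24 log units; within the scatter), and the two replacing groups also cannot be separated, with a 1.1-fold higher number from compound 2 to compound 4 (0.05 log units; within the scatter). Where the earlier compounds offered a single step at this place, there are now three groups, 2,6-dichlorophenyl, 4-nitrophenyl and 3-bromophenyl, and none of the steps among them lies beyond the scatter, so this small set shows no order among these three phenyl groups. Compound 3 remains a limit and not a number, and it differs from the others in more than one place, so it adds no step to this comparison: the limit of > 50000 nM in this assay, at which 1 of the 4 values shown sits.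

Every group shown at this place is a substituted phenyl ring, so it remains open whether an unsubstituted phenyl, a saturated alkyl chain, an amine or a carboxylic acid at the same place would give a value within the scatter of these three. The compounds shown also leave open whether any change at this place can move the value beyond the scatter at all.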